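This account rests on a few compounds, and the source may have more. Where it says the series, first, only, none or still open, it means among the compounds named here.

Compound 3 `O=C1N(CCCCCCOc2ccc(C(F)(F)F)cc2)CCN1c1cccnc1` belongs to a small set sharing one core, alongside compound 1 `O=C1N(CCCCCCOc2ccc(C(F)(F)F)cc2)CCN1c1ccncc1` and compound 2 `O=C1N(CCCCCCOc2ccc(C(F)(F)F)cc2)CCN1c1ccnc(Cl)c1`. In a functional assay on cells (Homo sapiens) for cytotoxicity (a higher number here means that more compound is tolerated, a lower number that less compound is tolerated), compound 1 gives > 25000 nM, which is a limit of the assay rather than a number. In this assay compound 2 likewise gives > 25000 nM, again a limit. In this assay compound 3 gives > 25000 nM, also a limit. Where compound 3 stands on the numbers is therefore open: the steps a step that the two limits leave unreadable from compound 1 to compound 3 and a step that the two limits leave unreadable from compound 2 to compound 3 cannot be read, just as the step that the two limits leave unreadable from compound 1 to compound 2 cannot, because every value shown sits at the limit of > 25000 nM in this assay, at which 3 of the 3 values shown sit.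

Compound 4 `O=C1N(CCCCCCOc2ccc(C(F)(F)F)cc2)CCN1c1ccncn1` differs from compound 3 by pyrimidin-4-yl in place of pyridin-3-yl on an amide-type nitrogen in a ring. For the measured compounds named here, no measured step bears on this change directly; the three measured steps, all unreadable, show only that exchanging one pyridinyl for another, or adding a chloro, left each compound at the limit. Compound 4 is therefore expected to sit at the limit as well, with the step that the limit leaves unreadable from compound 3 to compound 4 estimated as nothing beyond the scatter. For compound 4 in this assay the estimate is 30000 nM, with a range from 15000 nM to 100000 nM.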

Compound 4, half-maximal cytotoxic concentration: > 25000 nM
Compound 4 ended at the assay's limit; the forecaster's own chance of this, stated with the estimate: 85%; the middle value does not contradict the limit.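

In this assay compound 4 gives > 25000 nM as a limit, not a number. The steps from compound 1, compound 2 and compound 3 to compound 4 cannot be read, because all four values stand at one limit: the limit of > 25000 nM in this assay, at which 4 of the 4 values shown sit. The compounds shown leave open whether these groups on the amide-type nitrogen differ in cytotoxicity at all.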